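Thiosemicarbazone of a Monoterpene Alcohol: Changing the Aryl Group

The compounds below may be only part of what the source reports. "The series", "measured", "known", "first", "only" and "open" are said of these compounds alone.

Measured compounds:
- compound 1, `CC1=CC[C@@H]([C@@](C)(O)CCCC(C)(C)NC=S)CC1`: 93700 nM
- compound 2, `CC1=CC[C@@H]([C@@](C)(O)CCCC(C)(C)NC(=S)N/N=C\c2ccc(C)cc2)CC1`: 11800 nM

Both compounds were tested in a functional assay on OVCAR-3 cells (Homo sapiens) for cytotoxicity, read by sulforhodamine B assay; on this read-out higher numbers stand for weaker inhibition of growth and lower numbers for stronger inhibition of growth. Compound 1, which carries only a thioformamide on the nitrogen, gives 93700 nM. Compound 2, where that group is extended into a thiosemicarbazone bearing a 4-methylphenyl ring, gives 11800 nM. Of the two numbers, compound 2 has the lower one, and the gap to compound 1 lies beyond the usual scatter, so compound 2 is the stronger growth inhibitor among the two.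

The next step keeps the whole thiosemicarbazone framework of compound 2 and changes only the aromatic ring: 2-nitrophenyl in place of 4-methylphenyl on a carbon with a double bond to nitrogen. This gives compound 3, `CC1=CC[C@@H]([C@@](C)(O)CCCC(C)(C)NC(=S)N/N=C\c2ccccc2[N+](=O)[O-])CC1`. Within the data shown here, no pair of measured compounds shows what such a change in the aryl group does here, so the direction cannot be read from the data. The step from compound 2 to compound 3 is therefore expected to be small, most likely no larger than the scatter, as expressed by a 1.3-fold higher number from compound 2 to compound 3 (0.10 log units; within the scatter). Compound 3 is expected to give about 15000 nM in this assay, with a plausible range from 5000 nM to 45000 nM.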

Compound 3, concentration for total growth inhibition: 16200 nM
The estimate for compound 3 lay 1.1-fold (0.03 log units) below the measured number; low and high end bracket the measured number.
By their numbers in this assay, from the lowest: compounds 2 and 3 (each within the scatter of the next); then compound 1.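

In this assay, placing 2-nitrophenyl in place of 4-methylphenyl on a carbon with a double bond to nitrogen gives a 1.4-fold higher number from compound 2 to compound 3 (0.14 log units; within the scatter), so the two numbers cannot be told apart. Among these compounds, this is the first direct look at this position, and it shows that the aromatic ring can be exchanged here without a change that stands out from the scatter, even though 2-nitrophenyl brings nitrogen, oxygen and hydrogen-bond acceptors that 4-methylphenyl lacks. No measurement is available that could explain why the two rings give such similar numbers.

This single exchange cannot show how far that tolerance reaches, since a ring carrying an amine or a carboxylic acid, or a longer chain in place of the ring, might behave quite differently. It also leaves open whether the similarity of these two compounds would hold on other cell lines, or whether changes elsewhere in the shared framework, such as at the hydroxyl group, matter more than the choice of aryl group.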